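The compounds below may be only part of what the source reports. "The series", "measured", "known", "first", "only" and "open" are said of these compounds alone.

For the measured compounds named here, compound 2 `CC(C)(C)c1cc(NC(=O)[C@@H]2CCCCN2C(=O)N2CCCCC2)no1` gives 0.233 h in an ADME assay (liver) for metabolic stability, with Liver microsome (Homo sapiens) as the target, read by LC-MS, using microsomes and NADPH, tested at 1 uM (a lower number here means that the compound disappears faster, a higher number that the compound lasts longer), the lower of the two numbers measured so far. Compound 1 `CC(C)(C)c1cc(NC(=O)[C@@H]2CCCCN2C(=O)c2ccccc2)no1` gives 0.683 h in this assay, and the step of a 2.9-fold lower number from compound 1 to compound 2 (0.47 log units; beyond the scatter) is the only one on record. Compound 3 `CCC(=O)N1CCN(C(=O)N2CCCC[C@H]2C(=O)Nc2cc(C(C)(C)C)on2)CC1` differs from compound 2 by 4-propanoylpiperazin-1-yl in place of piperidin-1-yl on a carbonyl carbon. Going by the values given here, no measured step covers this exchange, and the one measured step concerns a different group on the same carbonyl carbon and was modest in size. For compound 3 a step of at most similar size is expected, with no firm direction, so a 1.3-fold higher number from compound 2 to compound 3 (0.11 log units; within the scatter). Compound 3 is therefore estimated at 0.3 h, within 0.1 h to 0.9 h.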

Compound 3, half-life: > 2 h
Compound 3: a limit, no number; the forecaster's own chance of this, stated with the estimate: 5%; at least 6.6-fold (0.82 log units) between middle value and limit.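

On the carbonyl carbon, 4-propanoylpiperazin-1-yl in place of piperidin-1-yl gives an at least 8.5-fold higher number from compound 2 to compound 3 (0.93 log units; beyond the scatter), so this place can shift the read-out in the upward direction as well. In place of phenyl, the same group gives an at least 2.9-fold higher number from compound 1 to compound 3 (0.46 log units; beyond the scatter), which puts compound 3 beyond both earlier compounds. In this assay compound 3 stands at a limit of the assay, not a number: the limit of > 2 h in this assay, at which 1 of the 3 values shown sits.

On these data alone, how far compound 3 lasts past that limit remains open. Also open, as far as these compounds go, is whether the propanoyl chain or the second ring nitrogen carries the change, which a piperazine with a free amine or an acetyl group could separate.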